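The source may hold more compounds than are shown below. What is called first, only, known or untested is meant among the compounds shown, and "the series" means these compounds.

Working notes on the series. Compound 1 `CN(C(=O)c1cc(C(F)(F)F)cc(C(F)(F)F)c1)N(CCC(=O)N[C@@H]1CCCCNC1=O)Cc1cc(Br)c(Br)s1` and compound 2 `CN(C(=O)c1cc(C(F)(F)F)cc(C(F)(F)F)c1)N(CCC(=O)N[C@@H]1CCCCNC1=O)Cc1ccc(Cl)c(Cl)c1` share the same core and differ only in the group on a saturated chain carbon bound to an amine nitrogen. In an assay (Bos taurus) for binding affinity to Substance-P receptor (Homo sapiens), read by radioligand binding (a higher number here means a weaker inhibitor, a lower number a stronger inhibitor), compound 1 gives 18 nM, and compound 2 gives 1.4 nM. The step of a 13-fold lower number from compound 1 to compound 2 (1.11 log units; beyond the scatter) is the only one measured so far, and it leaves compound 2 at the lowest of the two numbers, with compound 1 the nearest at a clearly higher number. Compound 3 `CN(C(=O)c1cc(C(F)(F)F)cc(C(F)(F)F)c1)N(CCC(=O)N[C@@H]1CCCCNC1=O)Cc1ccc2ccccc2c1` is not yet measured; it differs from compound 2 by naphthalen-2-yl in place of 3,4-dichlorophenyl on a saturated chain carbon bound to an amine nitrogen. Among the measured compounds shown here, no measured step bears directly on this change: the single step of a 13-fold lower number from compound 1 to compound 2 (1.11 log units; beyond the scatter) swaps one of those two groups for the other and shows only that the number moves strongly with what sits at this position, not how a naphthalen-2-yl group will read. The expected outcome for compound 3 in this assay is therefore a modest rise in the number, a 2.1-fold higher number from compound 2 to compound 3 (0.33 log units; beyond the scatter), close to the edge of the scatter. Compound 3 is estimated at 3 nM, with a range from 0.8 nM to 12 nM.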

Compound 3, half-maximal inhibitory concentration: 6.4 nM
The estimate for compound 3 lay 2.1-fold (0.33 log units) below the measured number; measured number inside the range.
By their numbers in this assay, from the lowest: compound 2; then compound 3; then compound 1.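

In this assay, the step of a 4.6-fold higher number from compound 2 to compound 3 (0.66 log units; beyond the scatter) shows that an all-carbon group with two six-membered aromatic rings and no chlorine still reads clearly lower at this position than the 4,5-dibromothiophen-2-yl group, but does not match 3,4-dichlorophenyl. The step of a 2.8-fold lower number from compound 1 to compound 3 (0.45 log units; beyond the scatter) places naphthalen-2-yl between the two earlier groups, so the three compounds form an order in which every gap lies beyond the scatter, and halogen atoms on the group do not by themselves set that order, since compound 1 carries two bromines and still gives the highest number. Nothing measured here accounts for this order on a saturated chain carbon bound to an amine nitrogen.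

The compounds shown leave open how much of the low number of compound 2 rests on its two chlorines, which an unsubstituted phenyl or a phenyl with a single chlorine would test directly. They also leave open whether a ring nitrogen, as in a quinolinyl group, would keep the reading of naphthalen-2-yl, and whether a longer chain between the amine nitrogen and the ring would be tolerated.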